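Aminophenyl in place of pyridyl on a triazole core

The compounds below may be only part of what the source reports. "The series", "measured", "known", "first", "only" and "open" are said of these compounds alone.

In an assay on cells for inhibition of ubiquitin carboxyl-terminal hydrolase isozyme L5 (Homo sapiens), read by fluorescence, with a stated time of 30 min (on this read-out higher numbers stand for weaker inhibition and lower numbers for stronger inhibition), compound 1 `CC(=O)Nc1cccc(-c2cn(Cc3cc(C(=O)O)cc(-c4ccccc4C(=O)O)c3)nn2)c1` gives 96200 nM.
In this assay compound 2 `Nc1ccc(-c2cn(Cc3cc(C(=O)O)cc(-c4ccccc4C(=O)O)c3)nn2)cc1` gives 80500 nM.
In this assay compound 3 `O=C(O)c1cc(Cn2cc(-c3cccnc3)nn2)cc(-c2ccccc2C(=O)O)c1` gives 252000 nM.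

Compound 3 has the highest number of the three, beyond the scatter from both compound 1 and compound 2. Compound 4 `Nc1cccc(-c2cn(Cc3cc(C(=O)O)cc(-c4ccccc4C(=O)O)c3)nn2)c1` differs from compound 3 by 3-aminophenyl in place of pyridin-3-yl on an aromatic carbon. For the measured compounds named here, the steps that bear on this change are a 3.1-fold higher number from compound 2 to compound 3 (0.50 log units; beyond the scatter) and a 2.6-fold higher number from compound 1 to compound 3 (0.42 log units; beyond the scatter), both modest and both running toward the weaker side. Reversing such a change is therefore expected to bring a modest step downward in this assay, roughly the size of the step from compound 2 to compound 3. For compound 4 the expected step is a 2.8-fold lower number from compound 3 to compound 4 (0.45 log units; beyond the scatter), and its number in this assay is estimated at 90000 nM, within a range from 40000 nM to 200000 nM.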

Compound 4, half-maximal inhibitory concentration: 72600 nM
Compound 4: middle estimate off by 1.2-fold (0.09 log units), on the high side, and the stated range covers the measured number.
By their numbers in this assay, from the lowest: compounds 4, 2 and 1 (each within the scatter of the next); then compound 3.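

In this assay, the advantage of an aminophenyl over pyridin-3-yl on this aromatic carbon (a 3.5-fold lower number from compound 3 to compound 4 (0.54 log units; beyond the scatter)) does not depend on where the amine sits, as 3-aminophenyl and 4-aminophenyl are not separated beyond the scatter (a 1.1-fold lower number from compound 2 to compound 4 (0.04 log units; within the scatter)). The acetyl on the nitrogen likewise makes no difference beyond the scatter (a 1.3-fold lower number from compound 1 to compound 4 (0.12 log units; within the scatter)). Nothing given here accounts for these results. As far as these compounds go, it remains open whether a hydroxyl, a carboxylic acid or an aminomethyl group in place of the amine would keep the number of compound 4 (72600 nM).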